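Swapping the amine ring on an indole sulfone

The compounds below may be only part of what the source reports. "The series", "measured", "known", "first", "only" and "open" are said of these compounds alone.

Compound 2 `O=S(=O)(c1cccc(F)c1)c1cn(C2CCCNC2)c2ccc(F)cc12`: 18 nM
Compound 1 `CN1CCC(n2cc(S(=O)(=O)c3cccc4cccnc34)c3ccccc32)C1`: 76 nM

In a functional assay on HeLa cells for antagonist activity at 5-hydroxytryptamine receptor 6 (Homo sapiens), read by cAMP accumulation and immunoassay, with a stated time of 10 min (on this read-out lower numbers stand for stronger inhibition and higher numbers for weaker inhibition), compound 2 gives 18 nM, the lower of the two numbers measured; compound 1 gives a higher number, and that gap lies beyond the usual scatter. Compound 3 `CN1CCC(n2cc(S(=O)(=O)c3cccc(F)c3)c3cc(F)ccc32)C1` has the same atoms as compound 2, joined differently: 1-methylpyrrolidin-3-yl in place of piperidin-3-yl on an aromatic nitrogen. Compound 1 carries the same entering ring on a different sulfonyl aryl, so no direct comparison exists. Compound 3 is expected to give a slightly weaker number, a step from compound 2 to compound 3 of about a 2.2-fold higher number from compound 2 to compound 3 (0.35 log units; beyond the scatter), near the edge of the scatter. The estimate for compound 3 is 40 nM, within 12 nM to 130 nM.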

Compound 3, half-maximal inhibitory concentration: 94 nM
The estimate for compound 3 lay 2.4-fold (0.37 log units) below the measured number, and the stated range covers the measured number.
By their numbers in this assay, from the lowest: compound 2; then compounds 1 and 3 (each within the scatter of the next).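

In this assay, within the data shown here, putting 1-methylpyrrolidin-3-yl in place of piperidin-3-yl on an aromatic nitrogen produces a 5.2-fold higher number from compound 2 to compound 3 (0.72 log units; beyond the scatter) and gives the first direct reading at this position, with the shared core and sulfonyl aryl held fixed. It shows that potency here depends on which amine ring is attached. No measurement shown here explains the step.

The compounds shown do not separate ring size from the methyl group on the ring nitrogen. Pyrrolidin-3-yl and 1-methylpiperidin-3-yl at this position would tell those two changes apart.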